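A few compounds are considered here, and "the series" means these few. Any claim that something is new, unique, unknown or untested is made for them only; others in the source may bear on it.

Working notes on two measured compounds and one untested analogue sharing a core. Compound 1 `CCC[C@@H](OC(C)=O)C1=C(Br)C(=C(Br)Br)OC1=O` carries an acetoxy group; in a functional assay on LNCaP cells (Homo sapiens) for cytotoxicity (a lower number here means that less compound is needed, a higher number that more compound is needed for the effect), compound 1 gives 2.1 ug/mL. Compound 2 `CCC[C@@H](OC(C)=O)C1=C(Br)[C@@](CI)(OC)OC1=O` has a modified core; in this assay compound 2 gives 12.9 ug/mL. Of the two numbers, that of compound 1 is the lower one, and the gap to compound 2 lies beyond the usual scatter. Among the measured compounds shown here, no pair of measured compounds differs in a single place, so no measured single-change step is available to calibrate the next comparison.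

Compound 3 `CCCCC1=C(Br)C(=C(Br)Br)OC1=O` differs from compound 1 in one place: hydrogen in place of acetoxy on a saturated chain carbon bound to a double-bonded ring carbon and a saturated chain carbon. Nothing measured here isolates the contribution of the acetoxy group, so the expectation rests on compound 1 alone. The step of a 1.7-fold higher number from compound 1 to compound 3 (0.22 log units; within the scatter) is expected to be small, at most a modest rise in the concentration needed, and it may well fall within the scatter. Compound 3 is estimated at 3.5 ug/mL in this assay, with a plausible range from 1.2 ug/mL to 10 ug/mL.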

Compound 3, concentration for half-maximal effect: 9.3 ug/mL
Compound 3: middle estimate off by 2.7-fold (0.42 log units), on the low side; the measured number falls inside the stated range.
By their numbers in this assay, from the lowest: compound 1; then compounds 3 and 2 (each within the scatter of the next).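

In this assay, among the compounds shown here, hydrogen in place of acetoxy on a saturated chain carbon bound to a double-bonded ring carbon and a saturated chain carbon gives a 4.4-fold higher number from compound 1 to compound 3 (0.65 log units; beyond the scatter) and so provides the first measured single-change step. For the compounds shown here, this shows that the position is sensitive to this exchange on the core of compound 1, as the step lies beyond the scatter and the compound with acetoxy is the one that needs less compound for the effect. The compounds shown come with no separate measurement that could explain the rise, so the step stands as a description of the exchange alone.

Open, from the compounds shown here alone, is whether the whole acetoxy group matters or only part of it, a question that a hydroxyl group or a methoxy group on this carbon would address. Also open, going by these compounds, is whether the same exchange would give a step of similar size on the core of compound 2, and how a benzoate ester or an amine on this carbon would compare with acetoxy.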